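Nitro to trifluoromethyl in a small series

The source may report more compounds than this note shows. Statements on the series, on what has been measured and on what is new or still open speak of the compounds shown alone.

Three compounds share one core and differ only in a single side group. In a functional assay (aorta) with Oryctolagus cuniculus as the target (on this read-out lower numbers stand for stronger inhibition and higher numbers for weaker inhibition), compound 1 `COCCO/C(O)=C1\C(C)=NC(C)=C(C(=O)OCCCN2C(=O)c3ccccc3S2(=O)=O)C1c1ccccc1[N+](=O)[O-]` gives 2.7 nM, compound 2 `CC1=NC(C)=C(C(=O)OCCCN2C(=O)c3ccccc3S2(=O)=O)C(c2ccccc2[N+](=O)[O-])/C1=C(\O)OCC1CCCO1` gives 6.8 nM and compound 3 `CC1=NC(C)=C(C(=O)OCCCN2C(=O)c3ccccc3S2(=O)=O)C(c2ccccc2[N+](=O)[O-])/C1=C(\O)OCC1CCCCO1` gives 11.5 nM. Compound 2 therefore lies within the scatter of compound 3, while compound 1 stands apart from it on the lower side, beyond the scatter.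

The next compound, compound 4 `CC1=NC(C)=C(C(=O)OCCCN2C(=O)c3ccccc3S2(=O)=O)C(c2ccccc2C(F)(F)F)/C1=C(\O)OCC1CCCO1`, keeps the oxolan-2-yl group of compound 2 but carries trifluoromethyl in place of nitro on an aromatic carbon, ortho to a large group, so that 2-nitrophenyl becomes 2-(trifluoromethyl)phenyl: trifluoromethyl in place of nitro on an aromatic carbon.

Within the data shown here, no measured step touches that aromatic carbon. All three change the group on the saturated chain carbon: a 2.5-fold higher number from compound 1 to compound 2 (0.40 log units; beyond the scatter), a 4.3-fold higher number from compound 1 to compound 3 (0.63 log units; beyond the scatter) and a 1.7-fold higher number from compound 2 to compound 3 (0.23 log units; within the scatter). These steps show only how far this assay has moved within this small set, modestly at most, and they offer no direct guide to the new change. The expected change is a 1.8-fold higher number from compound 2 to compound 4 (0.25 log units; within the scatter), a lean towards a higher number that is not expected to stand clearly beyond the scatter. The estimate for compound 4 is 12 nM, with an expected range from 4 nM to 36 nM.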

Compound 4, half-maximal inhibitory concentration: 3.7 nM
Beside the measured number, compound 4's estimate is 3.2-fold (0.51 log units) above it; the whole stated range lies above it.
By their numbers in this assay, from the lowest: compounds 1, 4, 2 and 3 (each within the scatter of the next, the first and the last beyond it).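

Among the compounds shown, only this step touches the aromatic carbon, and in this assay it reads as a 1.8-fold lower number from compound 2 to compound 4 (0.26 log units; within the scatter). The two values cannot be told apart, so with the oxolan-2-yl group in place, the nitro group is not needed on this carbon for activity at this level: compound 4, whose trifluoromethyl group counts no hydrogen-bond acceptors, gives 3.7 nM in this assay, and the change of group at this position registers no more clearly than the step between the two ring-bearing side chains, a 1.7-fold higher number from compound 2 to compound 3 (0.23 log units; within the scatter). Nothing shown bears on what lies behind this result.

On these data alone, it remains open whether the same exchange would also leave the read-out unmoved when the methoxymethyl group of compound 1 or the oxan-2-yl group of compound 3 sits on the side chain, since trifluoromethyl is seen here with oxolan-2-yl alone. As far as these compounds go, how far this aromatic carbon tolerates other replacements also stays unknown, for example a nitrile, a chlorine atom, a methoxy group or an amine in the place of nitro.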